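The source may report more compounds than this note shows. Statements on the series, on what has been measured and on what is new or still open speak of the compounds shown alone.

Measured compounds in a functional assay on HepG2 cells (Homo sapiens) for antiproliferative activity, with a stated time of 72 h; a lower number here means that less compound is needed, a higher number that more compound is needed for the effect:

Compound 1 `C=CCNC(=O)n1c(-c2ccc(OC)cc2)cc(=O)c2c(OC)cc(OC)cc21` gives > 20000 nM, which is a limit of the assay, not a number.

Compound 2 `COc1ccc(-c2cc(=O)c3c(OC)cc(OC)cc3n2S(=O)(=O)c2ccc([N+](=O)[O-])cc2)cc1` gives > 29300 nM, again only a limit.

Compound 3 `COc1ccc(-c2cc(=O)c3c(OC)cc(OC)cc3n2S(=O)(=O)c2ccc(C#N)cc2)cc1` gives > 17200 nM, also a limit.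

For the measured compounds named here, compound 3 thus stands nowhere on a number scale: all three values shown are limits, and no compound among them has a measured effect. The two steps that lead to compound 3 are a step that the two limits leave unreadable from compound 1 to compound 3 and a step that the two limits leave unreadable from compound 2 to compound 3; neither can be read, because each end sits at a limit, as the limit of > 17200 nM in this assay, at which 1 of the 3 values shown sits, the limit of > 20000 nM in this assay, at which 1 of the 3 values shown sits, and the limit of > 29300 nM in this assay, at which 1 of the 3 values shown sits, record.

Compound 4 `COc1ccc(-c2cc(=O)c3c(OC)cc(OC)cc3n2S(=O)(=O)c2ccc(OC)cc2)cc1` differs from compound 3 by methoxy in place of cyano on an aromatic carbon. Going by the values given here, no measured step bears on this change with a readable size, so nothing in the data points to a gain or loss beyond the scatter. The expected step is therefore a step that the limit leaves unreadable from compound 3 to compound 4, a move of no readable size. Compound 4 is expected to give about 20000 nM in this assay, within 7000 nM to 60000 nM, most likely again reported only as a limit.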

Compound 4, half-maximal effective concentration: > 82700 nM
Compound 4 gave a limit, no number; the forecaster's own chance of this, stated with the estimate: 80%; middle value at least 4.1-fold (0.61 log units) from the limit.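

Compound 4 gives > 82700 nM, again a limit and not a number. All four values are limits, so its steps from compound 1, compound 2 and compound 3 cannot be read. The compounds shown leave open whether any group on the shared core gives a measurable effect in this assay, and so how methoxy, cyano and nitro compare.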